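The source may hold more compounds than are shown below. What is called first, only, known or untested is meant among the compounds shown, and "the series" means these compounds.

In an ADME assay on microsomes from liver (Rattus norvegicus) for metabolic stability, read by LC-MS, using NADPH, with a stated time of 10 min, tested at 0.1 uM (on this read-out lower numbers stand for slow clearance and higher numbers for fast clearance), three related compounds have been measured: compound 1 (`CC1SC(c2cccc(C(=O)NCCCCc3ccccc3)c2)N(c2ccc(C3CC3)cc2)C1=O`) gives 3130 mL.min-1.g-1, compound 2 (`COc1ccccc1N1C(=O)CSC1c1cc(F)cc(C(=O)NCCCCc2ccccc2)c1`) gives 3260 mL.min-1.g-1, and compound 3 (`O=C(NCCCCc1ccccc1)c1cccc(C2SCC(=O)N2c2cccc(-c3c[nH]nn3)c2)c1`) gives 742 mL.min-1.g-1. Compound 3 has the lowest number of the three, and its gaps to the other two lie beyond the scatter. Compound 4 (`O=C(NCCCCc1ccccc1)c1cccc(C2SCC(=O)N2c2ccccc2F)c1`) differs from compound 3 on an amide-type nitrogen in a ring, where a 2-fluorophenyl group enters: a group of 7 heavy atoms (6 carbon, 1 fluorine; one six-membered aromatic ring of carbon only) in place of a group of 11 heavy atoms (8 carbon, 3 nitrogen; one five-membered aromatic ring with 3 hetero atoms, one six-membered aromatic ring of carbon only), on an amide-type nitrogen in a ring. A rise beyond the scatter is expected in this assay because compound 2, which also lacks the five-membered aromatic ring, gives 3260 mL.min-1.g-1. The expected change is a 3.4-fold higher number from compound 3 to compound 4 (0.53 log units; beyond the scatter). Compound 4 is estimated at 2500 mL.min-1.g-1, with an expected range of 1100 mL.min-1.g-1 to 5000 mL.min-1.g-1.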

Compound 4, intrinsic clearance in microsomes: 2950 mL.min-1.g-1
Beside the measured number, compound 4's estimate is 1.2-fold (0.07 log units) below it, and the stated range covers the measured number.
By their numbers in this assay, from the lowest: compound 3; then compounds 4, 1 and 2 (each within the scatter of the next).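

With the rest of the molecule unchanged, placing 2-fluorophenyl on the amide-type nitrogen in a ring gives a 4.0-fold higher number from compound 3 to compound 4 (0.60 log units; beyond the scatter) in this assay. Going by these compounds alone, this ties the low number of compound 3 to the group at this one position, which the earlier compounds, differing in more than one place, could not do. Nothing available explains the step.

The step exchanges the whole group, so the share of the five-membered aromatic ring and that of the fluorine remain apart and unknown. Going by these compounds, whether a tetrazole or a carboxylic acid on the phenyl ring would give a low number is also open.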